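The source may report more compounds than this note shows. Statements on the series, on what has been measured and on what is new or still open speak of the compounds shown alone.

Measured in a functional assay on A549 cells (Homo sapiens) for antiproliferative activity, read by MTT assay, with a stated time of 24 h; on this read-out higher numbers stand for weaker inhibition and lower numbers for stronger inhibition:
- Compound 1 `O=S(=O)(c1ccccc1)n1c(-c2cn(-c3ccccc3)nc2-c2ccc(C(F)(F)F)cc2)nc2ccccc21`: 480 nM
- Compound 2 `O=[N+]([O-])c1ccc(S(=O)(=O)n2c(-c3cn(-c4ccccc4)nc3-c3ccc(C(F)(F)F)cc3)nc3ccccc32)cc1`: 790 nM

Against compound 1, its only comparison, compound 2 at 790 nM lies within the scatter, so the two values mark a single level. Compound 3 `O=S(=O)(c1ccc(F)cc1)n1c(-c2cn(-c3ccccc3)nc2-c2ccc(C(F)(F)F)cc2)nc2ccccc21`, not yet measured, carries fluoro in place of nitro on an aromatic carbon, para to a large group: fluoro in place of nitro on an aromatic carbon. For the measured compounds named here, only one measured step bears on this change: a 1.6-fold higher number from compound 1 to compound 2 (0.22 log units; within the scatter), with nitro in place of hydrogen on an aromatic carbon. Going by the values given here, no measured compound carries fluoro, so the data offer no direct comparison for that group. On the strength of a 1.6-fold higher number from compound 1 to compound 2 (0.22 log units; within the scatter), no step beyond the scatter is expected in this assay. The expected step is a 1.4-fold lower number from compound 2 to compound 3 (0.16 log units; within the scatter). Compound 3 is estimated at 550 nM, with an expected range of 220 nM to 1400 nM.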

Compound 3, half-maximal inhibitory concentration: 1740 nM
Estimate against measurement, compound 3: 3.2-fold (0.50 log units) below; measured number above the stated range.
By their numbers in this assay, from the lowest: compounds 1 and 2 (each within the scatter of the next); then compound 3.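

In this assay, the aromatic carbon para to a large group proves sensitive to substitution, which the earlier pair did not show: nitro in place of hydrogen gave only a 1.6-fold higher number from compound 1 to compound 2 (0.22 log units; within the scatter), whereas fluoro in place of nitro gives a 2.2-fold higher number from compound 2 to compound 3 (0.34 log units; beyond the scatter) and fluoro in place of hydrogen gives a 3.6-fold higher number from compound 1 to compound 3 (0.56 log units; beyond the scatter). The step away from hydrogen therefore depends on the group that enters, and here the fluoro group, with one heavy atom, moves the number beyond the scatter, while the nitro group, with three, does not. Nothing at hand accounts for this difference between the two groups.

Going by these compounds, whether chloro, methoxy or an amine at this carbon would stay level with compound 1 or rise towards compound 3 remains open. So does whether fluoro would give a similar step at any other carbon of this ring.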